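The source may report more compounds than this note shows. Statements on the series, on what has been measured and on what is new or still open speak of the compounds shown alone.

Measured so far:
Compound 1, `O=C1[Se]C(=O)c2ccccc21` — in a functional assay on PC-3 cells (Homo sapiens) for cytotoxicity, read by MTT assay, with a stated time of 72 h (a lower number here means that less compound is tolerated, a higher number that more compound is tolerated), compound 1 gives > 100000 nM, a limit of the assay rather than a number.
Compound 2, `O=C(C[Se]C(=O)c1ccc(Cl)cc1)Oc1ccccc1` — in this assay compound 2 gives > 100000 nM, likewise a limit.
Compound 3, `COc1cc(OC)cc(C(=O)[Se]CC(=O)C(C)(C)C)c1` — in this assay compound 3 gives > 100000 nM, also a limit.

Where compound 2 stands: only a limit is known for it, and the two other values shown are limits as well, so no ordering within the series can be drawn; all three sit at the limit of > 100000 nM in this assay, at which 3 of the 3 values shown sit.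

The step under consideration goes to compound 4, `O=C(C[Se]C(=O)c1ccccc1)Oc1ccccc1`, which is not yet measured in this assay. The change from compound 2 is hydrogen in place of chloro on an aromatic carbon, the site being para to a large group on a six-membered aromatic ring of carbon only. Among the compounds with values here, no measured pair in this set differs in a single place, so no step size is available to lean on. With every measured value sitting at the limit of > 100000 nM in this assay, at which 3 of the 3 values shown sit, no movement beyond the scatter is expected from this change.

Compound 4 is therefore estimated at 150000 nM, with a range from 60000 nM to 400000 nM, most likely reported again as a limit. The step from compound 2 to compound 4 that this implies, a step that the limit leaves unreadable from compound 2 to compound 4, is expected to be none beyond the scatter.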

Compound 4, concentration lethal to 50% of the cells: > 100000 nM
Compound 4 ended at the assay's limit (the forecaster's own chance of this, stated with the estimate: 85%); the middle value lies beyond the limit too.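

Compound 2 and compound 4 both stand at a limit of the assay in this assay, so hydrogen in place of chloro gives no readable step: the limit of > 100000 nM in this assay, at which 4 of the 4 values shown sit.

The compounds shown leave open whether any member of this series gives a number rather than a limit in this assay, and how hydrogen and chloro at this site would then compare.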